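Shortening the aryl arm of a urea bile acid receptor ligand

The compounds below may be only part of what the source reports. "The series", "measured", "known", "first", "only" and "open" are said of these compounds alone.

The series shares one core. Compound 1 `COC(=O)/C=C/c1cccc(N(Cc2ccc(/C=C/c3c(C)cc(C)cc3C)cc2)C(=O)C(C)C)c1` gives 149 nM in an assay on isolated protein with Bile acid receptor (Homo sapiens) as the target; on this read-out higher numbers stand for an effect only at larger amounts of compound and lower numbers for an effect already at smaller amounts. Compound 2 `COC(=O)/C=C/c1cccc(N(Cc2ccc(/C=C/c3c(C)cc(C)cc3C)cc2)C(=O)NC(C)C)c1` gives 431 nM in this assay, and compound 3 `COC(=O)/C=C/c1cccc(N(Cc2ccc(/C=C/c3scnc3C)cc2)C(=O)C(C)C)c1` gives 228 nM. Compound 2 thus stands highest of the three numbers, beyond the scatter from compound 1 and within it from compound 3.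

The step toward compound 4 `COC(=O)/C=C/c1cccc(N(Cc2ccc(-c3ccc(C)cc3)cc2)C(=O)NC(C)C)c1` is 4-methylphenyl in place of 2-(2,4,6-trimethylphenyl)ethenyl on an aromatic carbon. Of the measured steps, only a 1.5-fold higher number from compound 1 to compound 3 (0.18 log units; within the scatter) touches the same part of the molecule, and it was within the scatter; a 2.9-fold higher number from compound 1 to compound 2 (0.46 log units; beyond the scatter) concerns the carbonyl substituent and carries no information about the aryl arm. For the measured compounds named here, no measured step removes the ethenyl link, so the present change is larger than anything observed, and the expectation is uncertain.

Compound 4 is therefore expected to give a somewhat higher number, estimated at 900 nM, with a range from 250 nM to 3500 nM. This estimate corresponds to an expected step of a 2.1-fold higher number from compound 2 to compound 4 (0.32 log units; beyond the scatter).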

Compound 4, half-maximal effective concentration: 449 nM
Estimate against measurement, compound 4: 2.0-fold (0.30 log units) above, within the range that was stated.
By their numbers in this assay, from the lowest: compounds 1, 3, 2 and 4 (each within the scatter of the next, the first and the last beyond it).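

Replacing the 2-(2,4,6-trimethylphenyl)ethenyl group with 4-methylphenyl in this assay gives a 1.0-fold higher number from compound 2 to compound 4 (0.02 log units; within the scatter), so with the isopropylamino carbonyl in place, this position accepts the loss of the double bond outside aromatic rings and a smaller count of heavy atoms with no shift beyond the scatter. The earlier step at this position, a 1.5-fold higher number from compound 1 to compound 3 (0.18 log units; within the scatter), exchanged only the ring on the ethenyl link, whereas this change removes the link itself. Nothing at hand explains why the number holds when the arm is shortened.

On these data alone, it remains open whether the same shortening would hold with isopropyl on the carbonyl, the group carried by compound 1 and compound 3. Also open, as far as these compounds go, is how a carboxylic acid in place of the methyl ester, or a 4-methoxyphenyl group on this aromatic carbon, would read out.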